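Removing the benzylamino group from compound 2

The source may report more compounds than this note shows. Statements on the series, on what has been measured and on what is new or still open speak of the compounds shown alone.

Of the compounds shown here, three on the shared core have numbers so far in a functional assay on U-373MG ATCC cells (Homo sapiens) for inhibition, read by MTT assay, with a stated time of 72 h (on this read-out lower numbers stand for stronger inhibition and higher numbers for weaker inhibition), and all three are weak. Compound 1 `CC1(C)CC(NC(=O)NCc2ccccc2)c2cc(Br)ccc2O1` gives 27000 nM in this read-out. Compound 2 `CC1(C)CC(NC(=O)NCc2ccccc2)c2cc(Cl)ccc2O1` gives 66000 nM in the same read-out. Compound 3 `CC1(C)CC(NC(=S)Nc2ccccc2)c2cc(Cl)ccc2O1` gives 46000 nM there too. Compound 2 sits at the high end of these numbers, within the scatter of compound 3 and beyond the scatter from compound 1.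

Still unmeasured is compound 4 `CC(=O)NC1CC(C)(C)Oc2ccc(Cl)cc21` and it differs from compound 2 by methyl in place of benzylamino on a carbonyl carbon alone. Among the measured compounds shown here, the one measured step is a 2.4-fold higher number from compound 1 to compound 2 (0.39 log units; beyond the scatter) with chloro in place of bromo on an aromatic carbon. That step is modest and sits at a different place, so it offers only a scale. For the measured compounds named here, no measured compound lacks the aromatic ring that leaves here, so the data hold no direct test. The expected change is a 2.3-fold higher number from compound 2 to compound 4 (0.36 log units; beyond the scatter) in this assay and this direction is tentative. For compound 4 the estimated value is 150000 nM with an expected range from 50000 nM to 400000 nM in this read-out.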

Compound 4, half-maximal inhibitory concentration: > 100000 nM
Compound 4 gave a limit, no number; the forecaster's own chance of this, stated with the estimate: 40%; the middle value does not contradict the limit.
By their numbers in this assay, from the lowest: compounds 1, 3 and 2 (each within the scatter of the next, the first and the last beyond it). At a limit, above all of these: compound 4.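

This is the first change shown at the carbonyl carbon in this assay, and methyl in place of benzylamino brings no gain there (an at least 1.5-fold higher number from compound 2 to compound 4 (0.18 log units; that floor lies within the scatter)) . Compound 4 gives > 100000 nM, which is a limit and not a number. The size of the change for losing the aromatic ring stays unfixed, and a real loss is not established, because only a floor can be read: the limit of > 100000 nM in this assay, at which 1 of the 4 values shown sits.

Open, on these data alone, is whether another group on the carbonyl carbon, such as dimethylamino or the longer phenethylamino chain, would give a measurable number in this assay, which would show how much of the benzylamino group matters. Also open, as far as these compounds go, is whether bromo in place of chloro on the aromatic carbon would have any readable effect with methyl on the carbonyl carbon.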